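Mirror-Image Analogue of Compound 3 in a Kinase Binding Assay

A few compounds are considered here, and "the series" means these few. Any claim that something is new, unique, unknown or untested is made for them only; others in the source may bear on it.

Measured so far, in a binding assay on isolated protein for inhibition of protein kinase C theta type (Homo sapiens), read by TR-FRET, with a stated time of 2 h; on this read-out lower numbers stand for stronger inhibition and higher numbers for weaker inhibition:
- compound 1, `N#Cc1cnc(NCc2cnccc2C(F)(F)F)cc1NC[C@H]1C[C@@H](O)C1`: compound 1 gives 300 nM
- compound 2, `N#Cc1cnc(NCc2cnccc2C(F)(F)F)cc1NCC1CCOCC1`: compound 2 gives 400 nM
- compound 3, `CC1(C)C[C@H](Nc2cc(NCc3cnccc3C(F)(F)F)ncc2C#N)CC[C@H]1O`: compound 3 gives 100 nM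

Compound 3 stands lowest of the three numbers, that is, it is the strongest binder here. Its margin over the others is modest but real: a 3.0-fold lower number from compound 1 to compound 3 (0.48 log units; beyond the scatter) and a 4.0-fold lower number from compound 2 to compound 3 (0.60 log units; beyond the scatter), both beyond the scatter. Between compounds 1 and 2 the change is only a 1.3-fold higher number from compound 1 to compound 2 (0.12 log units; within the scatter), so those two cannot be told apart.

Compound 4, `CC1(C)C[C@@H](Nc2cc(NCc3cnccc3C(F)(F)F)ncc2C#N)CC[C@@H]1O`, is the mirror image of compound 3: the two compounds have the same atoms and bonds and differ only in configuration as drawn: 2 of 2 stereo elements differ (all stereocentres are inverted: mirror images); a stereocentre at a saturated ring carbon is drawn R in compound 3 and S in compound 4; a stereocentre at a saturated ring carbon is drawn R in compound 3 and S in compound 4. All three measured steps swap one group on the aromatic nitrogen for another; none of them changes configuration, so none bears directly on this step. Mirror images often bind a protein differently, and the measured data give no way to say how much; the more common outcome is that one of the pair is weaker. Compound 4 is therefore expected to give a higher number, with a wide range of uncertainty, an estimated step of a 3.0-fold higher number from compound 3 to compound 4 (0.48 log units; beyond the scatter). The estimate for compound 4 in this assay is 300 nM, with a range from 80 nM to 1500 nM.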

Compound 4, half-maximal inhibitory concentration: 120 nM
Compound 4: middle estimate off by 2.5-fold (0.40 log units), on the high side; the measured number falls inside the stated range.
By their numbers in this assay, from the lowest: compounds 3 and 4 (each within the scatter of the next); then compounds 1 and 2 (each within the scatter of the next).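

In this assay, inverting both stereocentres of the 4-hydroxy-3,3-dimethylcyclohexyl group barely moves the number, with a 1.2-fold higher number from compound 3 to compound 4 (0.08 log units; within the scatter), so this assay does not tell the two mirror images apart. The earlier compounds shown here changed the group on the aromatic nitrogen but never its configuration, whereas this pair isolates configuration alone: the fact that compounds 3 and 4 differ only in the configuration as drawn. The margin of the 4-hydroxy-3,3-dimethylcyclohexyl group over the two earlier groups therefore does not depend on a single drawn configuration, since the mirror image keeps that margin too, with a 3.3-fold lower number from compound 2 to compound 4 (0.52 log units; beyond the scatter) and a 2.5-fold lower number from compound 1 to compound 4 (0.40 log units; beyond the scatter).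

Only the pair with both stereocentres inverted is shown, so the two forms with just one stereocentre inverted remain open, and these could behave differently from either mirror image. It is also unclear whether the hydroxy group or the two methyl groups account for the margin, a question that a cyclohexyl group carrying an amine in place of the hydroxy group, or one without the two methyl groups, could begin to answer.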